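Swapping a pyrimidine for a thiadiazole on a sulfur

This account rests on a few compounds, and the source may have more. Where it says the series, first, only, none or still open, it means among the compounds named here.

Of the compounds shown here, two sharing one core have been tested in a functional assay on C6 cells (Rattus norvegicus) for cytotoxicity, read by MTT assay, with a stated time of 24 h, tested at 100 ug/mL; on this read-out higher numbers stand for a weaker effect at the one concentration tested and lower numbers for a stronger effect. Compound 1, `Cc1nnc(SCC(=O)N/N=c2/scc(-c3ccc(Cl)cc3)n2-c2ccccc2)s1`, gives 34.1% in this assay. Compound 2, `Cc1ccc(-c2cs/c(=N/NC(=O)CSc3ncccn3)n2-c2ccccc2)cc1`, gives 45.9% in this assay, the higher of the two numbers, and the gap to compound 1 lies beyond the usual scatter. Compound 3, `Cc1ccc(-c2cs/c(=N/NC(=O)CSc3nnc(C)s3)n2-c2ccccc2)cc1`, has not yet been measured. It differs from compound 2 in a single place: 5-methyl-1,3,4-thiadiazol-2-yl in place of pyrimidin-2-yl on a sulfur. The same 5-methyl-1,3,4-thiadiazol-2-yl group on a sulfur is already present in compound 1, which carries a different group on its phenyl ring, so no exact match for this step exists among the measured pairs. A modest downward step, possibly no larger than the scatter, is expected, so that compound 3 is estimated to read 38% in this assay, within a range of 25% to 52%, which means an expected step of a number 7.9 percentage points lower from compound 2 to compound 3 (within the scatter).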

Compound 3, a percentage reported as activity, at one concentration (the size of the read-out at that concentration, not a potency): 31.5%
For compound 3 the middle estimate is 6.5 percentage points above the measured one, within the range that was stated.
By their numbers in this assay, from the lowest: compounds 3 and 1 (each within the scatter of the next); then compound 2.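

In this assay the change of pyrimidin-2-yl to 5-methyl-1,3,4-thiadiazol-2-yl on the sulfur gives a number 14.4 percentage points lower from compound 2 to compound 3 (beyond the scatter) and so shows that the group at this place can shift the read-out toward a stronger effect. With that group held fixed, methyl in place of chloro on an aromatic carbon gives a number 2.6 percentage points lower from compound 1 to compound 3 (within the scatter) and so leaves these two compounds indistinguishable in this read-out. No measurement shown here accounts for the difference between the two rings on the sulfur.

As far as these compounds go, whether a plain phenyl ring or an amine on this sulfur would read closer to the pyrimidin-2-yl or to the 5-methyl-1,3,4-thiadiazol-2-yl compound remains open. With a single concentration behind each number, these numbers speak only of a stronger or weaker effect at that concentration.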